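From methyl to trifluoromethyl in compound 3

A few compounds are considered here, and "the series" means these few. Any claim that something is new, unique, unknown or untested is made for them only; others in the source may bear on it.

Measured values in an ADME assay on cells (Hepatocyte, Mus musculus) for metabolic stability, with a stated time of 30 min (on this read-out lower numbers stand for a less stable compound and higher numbers for a more stable compound), are as follows

Compound 1 `CS(=O)(=O)NC1CCC(CN2CCN(c3cc(=O)c4cc(C(F)(F)F)cc([N+](=O)[O-])c4s3)CC2)CC1` gives 111%
Compound 2 `O=C(OC1CCC(CN2CCN(c3cc(=O)c4cc(C(F)(F)F)cc([N+](=O)[O-])c4s3)CC2)CC1)c1ccncc1` gives 1.4%
Compound 3 `Cc1ccc(C(=O)OC2CCC(CN3CCN(c4cc(=O)c5cc(C(F)(F)F)cc([N+](=O)[O-])c5s4)CC3)CC2)cc1` gives 18%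

Among these three, compound 3 stands second highest in this assay, with a number 16.6 percentage points higher from compound 2 to compound 3 (beyond the scatter) as a modest step and a number 93 percentage points lower from compound 1 to compound 3 (beyond the scatter) as a large one.

Compound 4 `O=C(OC1CCC(CN2CCN(c3cc(=O)c4cc(C(F)(F)F)cc([N+](=O)[O-])c4s3)CC2)CC1)c1ccc(C(F)(F)F)cc1` is the next to consider. It differs from compound 3 by trifluoromethyl in place of methyl on an aromatic carbon, which is trifluoromethyl in place of methyl on an aromatic carbon. For the measured compounds named here, no measured step makes this exchange. The closest is the modest step from compound 2, where 4-methylphenyl replaces pyridin-4-yl on the same carbonyl carbon. Going by the values given here, the large steps, a number 109.6 percentage points lower from compound 1 to compound 2 (beyond the scatter) and the one to compound 3, show that both compounds carrying the carbonyloxy group lie far below compound 1. Compound 4 keeps that group, so only a small downward change is expected, and it may not clear the usual scatter. The estimate amounts to a number 8 percentage points lower from compound 3 to compound 4 (within the scatter) as the expected step. Compound 4 is expected at 10%, within an estimated range of 1% to 28% as its ends.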

Compound 4, percent of the compound remaining: 28.8%
Estimate against measurement, compound 4: 18.8 percentage points below; measured number above the stated range.
By their numbers in this assay, from the lowest: compound 2; then compound 3; then compound 4; then compound 1.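

In this assay, the aromatic carbon para to a large group responds to substitution: with the ring and the carbonyloxy link kept in place, trifluoromethyl in place of methyl gives a number 10.8 percentage points higher from compound 3 to compound 4 (beyond the scatter). The 4-(trifluoromethyl)phenyl group also goes further beyond pyridin-4-yl than 4-methylphenyl did, with a number 27.4 percentage points higher from compound 2 to compound 4 (beyond the scatter), which puts compound 4 highest among the three carbonyloxy compounds, though compound 4 at 28.8% remains far under compound 1 at 111%. Nothing available here accounts for this difference between methyl and trifluoromethyl.

The compounds shown leave open how a methoxy group, a chlorine atom or a nitrile on the same aromatic carbon would compare. They also leave open whether an amide link in place of the carbonyloxy link would close the remaining gap to compound 1.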